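The compounds below may be only part of what the source reports. "The series", "measured", "known", "first", "only" and "open" are said of these compounds alone.

Measured so far:
compound 1, `COc1cccc(CCC(=O)N2CCN(c3ccc(C(F)(F)F)cc3[C@@H](N)CC(C)C)CC2)c1`, 4000 nM in an assay on HEK293 cells for displacement of a labelled ligand from Melanocortin receptor 4 (Homo sapiens); a lower number here means a stronger inhibitor, a higher number a weaker inhibitor
compound 2, `COc1ccc(CCC(=O)N2CCN(c3ccc(C(F)(F)F)cc3[C@@H](N)CC(C)C)CC2)cc1`, 350 nM

Going by the values given here, compound 2 has the lower of these two numbers, and the one step that separates them, an 11-fold lower number from compound 1 to compound 2 (1.06 log units; beyond the scatter), is large. Compound 3, `CC(C)C[C@H](N)c1cc(C(F)(F)F)ccc1N1CCN(C(=O)CCc2ccc(S(C)(=O)=O)cc2)CC1`, differs from compound 2 by methylsulfonyl in place of methoxy on an aromatic carbon. Among the compounds with values here, no measured step bears on this change; the only step seen concerns where the methoxy sits, not what replaces it. The expected step of a 1.2-fold lower number from compound 2 to compound 3 (0.07 log units; within the scatter) is therefore small and without clear direction. Compound 3 is estimated at 300 nM, within 80 nM to 1200 nM.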

Compound 3, inhibition constant: 4900 nM
Estimate against measurement, compound 3: 16-fold (1.21 log units) below; measured number outside the range, above it.
By their numbers in this assay, from the lowest: compound 2; then compounds 1 and 3 (each within the scatter of the next).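

The ring substituent matters as well as its placement: with the ring position held, methylsulfonyl in place of methoxy gives a 14-fold higher number from compound 2 to compound 3 (1.15 log units; beyond the scatter). Moving from 3-methoxyphenyl to 4-(methylsulfonyl)phenyl gives a 1.2-fold higher number from compound 1 to compound 3 (0.09 log units; within the scatter), so compound 1 and compound 3 cannot be told apart here, and only compound 2 stands out among the three. Nothing available explains this loss.

From the compounds shown here alone, it remains open whether a hydroxy group, a chlorine atom or an amine on this ring carbon would match compound 2, and whether any would give a lower number.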